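Methyl on the shared core: from compound 3 to compound 4

This account rests on a few compounds, and the source may have more. Where it says the series, first, only, none or still open, it means among the compounds named here.

Measured so far:
- compound 1, `Oc1cc(-c2ccc(Cl)cc2)nc2ncccc12`: 23400 nM
- compound 2, `Cc1ccnc2nc(-c3ccc(Cl)cc3)cc(O)c12`: 3160 nM
- compound 3, `COc1ccccc1-c1cc(O)c2cccnc2n1`: 47900 nM

In a functional assay on OVCAR-3 cells (Homo sapiens) (a higher number here means a weaker inhibitor of growth, a lower number a stronger inhibitor of growth), compound 1 gives 23400 nM. Compound 2 differs from compound 1 by one change, (methyl in place of hydrogen on an aromatic carbon), and in this assay compound 2 gives 3160 nM. That change made a 7.4-fold lower number from compound 1 to compound 2 (0.87 log units; beyond the scatter).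

Compound 3 differs from compound 1 in another part of the molecule; the difference between the two cores is not broken down here. In this assay compound 3 gives 47900 nM, the highest of the three numbers.

Compound 4, `COc1ccccc1-c1cc(O)c2c(C)ccnc2n1`, is not yet measured. It differs from compound 3 by methyl in place of hydrogen on an aromatic carbon, the same change that separates compound 1 from compound 2, at the same place. Resting on the step of a 7.4-fold lower number from compound 1 to compound 2 (0.87 log units; beyond the scatter), a step of similar size is expected here, though a single earlier example leaves room for a smaller effect: the estimate for the step is a 6.0-fold lower number from compound 3 to compound 4 (0.78 log units; beyond the scatter). Compound 4 is therefore expected to give about 8000 nM, likely between 3000 nM and 25000 nM.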

Compound 4, concentration for 50% growth inhibition: 12900 nM
Compound 4: middle estimate off by 1.6-fold (0.21 log units), on the low side; the measured number falls inside the stated range.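

In this assay, methyl in place of hydrogen on an aromatic carbon gives a 3.7-fold lower number from compound 3 to compound 4 (0.57 log units; beyond the scatter) and so moves the number the same way as on the core of compound 1. The step on the new core looks smaller, but the two steps cannot be told apart, so the change carries over in both direction and size as far as these data can show: the same change on two cores in this assay, a 7.4-fold lower number (0.87 log units; beyond the scatter) from compound 1 to compound 2 and a 3.7-fold lower number (0.57 log units; beyond the scatter) from compound 3 to compound 4, 2.0-fold (0.30 log units) apart, within the scatter of two such steps. Going by these compounds alone, this is still only two pairs of compounds in one kind of cell, with the methyl at one place, so it shows neither that the step would hold on other cores nor why the methyl lowers the number.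

The compounds shown leave open whether a larger group at this same place, such as an ethyl or a longer chain, would lower the number further or lose the gain. They also leave open what an amine or a carboxylic acid would do there, and whether a methyl on another carbon of this ring would give a similar step.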